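The compounds below may be only part of what the source reports. "The series", "measured", "known", "first", "only" and "open" are said of these compounds alone.

Working notes on the series.

In a functional assay on SF-295 cells (Homo sapiens) for inhibition, read by sulforhodamine B assay, with a stated time of 48 h, tested at 1 uM (on this read-out lower numbers stand for a stronger effect and higher numbers for a weaker effect at the one concentration tested), compound 3 `COc1cc(Cl)cc(-c2nn(-c3cccc(NC(=O)Nc4ccc(Cl)c(C(F)(F)F)c4)c3)cc2-c2ccncc2)c1` gives 31%, the lowest of the three numbers in hand. Compound 2 `O=C(Nc1cccc(-n2cc(-c3ccncc3)c(-c3cc(O)cc(Cl)c3)n2)c1)Nc1ccc(Cl)c(Cl)c1` gives 77% and compound 1 `O=C(Nc1cccc(-n2cc(-c3ccncc3)c(-c3cc(O)cc(Cl)c3)n2)c1)Nc1ccc(Cl)c(C(F)(F)F)c1` gives 91%; both stand higher than compound 3 beyond the scatter. The methyl on the oxygen is what sets compound 3 apart from compound 1, a change that read a number 60 percentage points lower from compound 1 to compound 3 (beyond the scatter), a large drop.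

Compound 4 `COc1cc(Cl)cc(-c2nn(-c3cccc(NC(=O)Nc4ccc(Cl)c(Cl)c4)c3)cc2-c2ccncc2)c1` differs from compound 3 only by the change (chloro in place of trifluoromethyl on an aromatic carbon), on the same ring that carries the chloro group. For the measured compounds named here, the one measured step bearing on this is the identical exchange within the pair that keeps the free hydroxyl, which gave a number 14 percentage points lower from compound 1 to compound 2 (beyond the scatter), a modest drop beyond the scatter. On that single precedent the same direction and about the same size are expected here, i.e. a number 11 percentage points lower from compound 3 to compound 4 (beyond the scatter), with the caveat that one pair is a thin basis and the lower starting number may compress the step.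

Compound 4 is therefore estimated at 20%, with a range of 5% to 38%.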

Compound 4, a percentage reported as activity, at one concentration (the size of the read-out at that concentration, not a potency): 70%
For compound 4 the middle estimate is 50 percentage points below the measured one, outside the stated range (above it).
By their numbers in this assay, from the lowest: compound 3; then compounds 4 and 2 (each within the scatter of the next); then compound 1.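

In this assay, chloro in place of trifluoromethyl gives a number 39 percentage points higher from compound 3 to compound 4 (beyond the scatter), so the outcome of this change at this position depends on whether the oxygen on the core carries a methyl or a hydrogen: the same change on two cores in this assay, a number 14 percentage points lower (beyond the scatter) from compound 1 to compound 2 and a number 39 percentage points higher (beyond the scatter) from compound 3 to compound 4, 53 percentage points apart, beyond the scatter of two such steps

Read the other way, the methyl on the oxygen gives a number 7 percentage points lower from compound 2 to compound 4 (within the scatter), so among these four compounds the low number of compound 3 appears only where the methyl and the trifluoromethyl occur together: the same change on two cores in this assay, a number 60 percentage points lower (beyond the scatter) from compound 1 to compound 3 and a number 7 percentage points lower (within the scatter) from compound 2 to compound 4, 53 percentage points apart, beyond the scatter of two such steps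

The compounds shown leave open whether a nitrile or a bromo in place of the trifluoromethyl, or an ethyl in place of the methyl on the oxygen, would read like compound 3 or like compound 4. They also leave open what underlies this dependence and whether it holds at other concentrations.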